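The compounds below may be only part of what the source reports. "The series", "measured", "known", "first", "only" and "open" are said of these compounds alone.

In an ADME assay on microsomes from liver (Mus musculus) for pharmacokinetics, read by LC-MS, using NADPH, with stated times of 5 min, 15 min and 30 min, tested at 10 uM (a lower number here means slower removal, a higher number faster removal of the compound), compound 1 `C[C@@H](c1ccc(NC(=O)N2CC(c3cccnc3)C2)cc1)N1Cc2ccccc2C1=O` gives 123 mL.min-1.g-1. Compound 2 `C[C@@H](c1ccc(NC(=O)N2CC(c3ccc(N)nc3)C2)cc1)N1Cc2ccccc2C1=O` gives < 25 mL.min-1.g-1, which is a limit of the assay and not a number. Compound 3 `C[C@H](NC(=O)c1cccc(F)c1)c1ccc(NC(=O)N2CC(c3ccc(N)nc3)C2)cc1` gives < 25 mL.min-1.g-1, which is also a limit. Compound 2 therefore has no exact value to start from, only a ceiling.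

Compound 4 `C[C@@H](c1ccc(NC(=O)N2CC(c3cncc(N)c3)C2)cc1)N1Cc2ccccc2C1=O` has the same atoms as compound 2, joined differently: 5-aminopyridin-3-yl in place of 6-aminopyridin-3-yl on a saturated ring carbon. The swap places 5-aminopyridin-3-yl in place of 6-aminopyridin-3-yl on a saturated ring carbon, and the rest of the molecule stays the same.

The most relevant measured change is an at least 4.9-fold lower number from compound 1 to compound 2 (0.69 log units; beyond the scatter), which came from amino in place of hydrogen on an aromatic carbon. The other measured change, a step that the two limits leave unreadable from compound 2 to compound 3, lies elsewhere in the molecule and gives no size to work with. Among the measured compounds shown here, compound 4 keeps the amino group, so it is expected to retain much of the drop seen in an at least 4.9-fold lower number from compound 1 to compound 2 (0.69 log units; beyond the scatter), though no measured pair shows what moving this group does.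

The estimated change is an at least 1.2-fold higher number from compound 2 to compound 4 (0.07 log units; that floor lies within the scatter), and any real shift is expected to be towards faster removal. For compound 4 the estimate in this assay is 30 mL.min-1.g-1, with an expected range from 12 mL.min-1.g-1 to 80 mL.min-1.g-1.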

Compound 4, intrinsic clearance in microsomes: 158 mL.min-1.g-1
For compound 4 the middle estimate is 5.3-fold (0.72 log units) below the measured one; measured number outside the range, above it.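

The new result shows that in this assay the mere presence of an amino group on this aromatic ring does not secure slow removal, since 5-aminopyridin-3-yl in place of 6-aminopyridin-3-yl, with the same atoms and the same counted features, gives an at least 6.3-fold higher number from compound 2 to compound 4 (0.80 log units; beyond the scatter). Compared with the parent that lacks the amino group, the 5-aminopyridin-3-yl compound shows a 1.3-fold higher number from compound 1 to compound 4 (0.11 log units; within the scatter), so the amino group placed this way leaves no readable effect, whereas the earlier compounds had shown only the large step for the 6-aminopyridin-3-yl group. The true size of the step from the isomer swap stays unknown, and only its floor can be read, as the starting compound has a limit of the assay rather than a number: the limit of < 25 mL.min-1.g-1 in this assay, at which 2 of the 4 values shown sit.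

The compounds shown do not explain why the placement of the amino group matters so much, and they do not show whether a hydroxyl or a methylamino group at either placement would behave like the amino group. From the compounds shown here alone, it also remains open whether 5-aminopyridin-3-yl would have the same effect in compound 3, which carries the fluorobenzamide side chain.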